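Swapping the Amide-Side Ring to Restore Dopamine D4 Activity

The source may hold more compounds than are shown below. What is called first, only, known or untested is meant among the compounds shown, and "the series" means these compounds.

The measured compounds:
compound 1, `O=C(CN1CCN(c2ccccn2)CC1)Nc1cccnc1`, gives 2660 nM;
compound 2, `O=C(CN1CCN(c2ccc(Cl)cn2)CC1)Nc1cncnc1`, is reported as "not active" (no number reported), with no number.

In an assay on cells for agonist activity at D(4) dopamine receptor (Homo sapiens), read by luminescence and beta-arrestin recruitment, with a stated time of 90 min (on this read-out higher numbers stand for an effect only at larger amounts of compound and lower numbers for an effect already at smaller amounts), compound 1 gives 2660 nM, a weak but measurable effect. Compound 2 stands apart: for compound 2 no single number is given, only the report "not active" (no number reported), meaning that no effect was seen in this assay. Compound 3, `O=C(CN1CCN(c2ccc(Cl)cn2)CC1)Nc1cccnc1`, is the next compound to be measured and has not yet been tested in this assay.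

Compound 3 differs from compound 2 in one place: pyridin-3-yl in place of pyrimidin-5-yl on an amide-type nitrogen. Among the compounds with values here, because no step between measured compounds is available, the size of this change can only be expected, not read off. Compound 3 carries the same pyridin-3-yl on the amide-type nitrogen as compound 1, and compound 1 gives 2660 nM, so an effect in the same weak region is plausible, which would be a move in the direction of lower numbers from the inactive compound 2, beyond the scatter. Compound 3 is expected to give about 3000 nM, between 800 nM and 15000 nM.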

Compound 3, half-maximal effective concentration: "not active" (no number reported)
For compound 3 the study gives words and no number, so the estimate cannot be set against anything.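

Compound 2 and compound 3 are both reported as not active in this assay, with no number, so no step can be read between them. No measurement shown offers an explanation for this result. The compounds shown leave open whether swapping pyrimidin-5-yl for pyridin-3-yl changes the effect at all; only compound 1 has a number, 2660 nM.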